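Sulfonyl alkyl variation on the fluorinated anilide

The source may report more compounds than this note shows. Statements on the series, on what has been measured and on what is new or still open speak of the compounds shown alone.

Compound 2 `CCS(=O)(=O)c1ccc(Nc2ncnc(N3CCC(c4nc(C(C)C)no4)CC3)c2[N+](=O)[O-])c(F)c1` gives 7 nM in a functional assay for agonist activity at Glucose-dependent insulinotropic receptor (Homo sapiens); a higher number here means that more compound is needed for the effect, a lower number that less compound is needed. Compound 1 `CC(C)c1noc(C2CCN(c3ncnc(Nc4ccc(S(=O)(=O)C(C)C)cc4)c3[N+](=O)[O-])CC2)n1` gives 7.8 nM in this assay, and the step of a 1.1-fold lower number from compound 1 to compound 2 (0.05 log units; within the scatter) leaves the two within the scatter of each other. Compound 3 `CC(C)c1noc(C2CCN(c3ncnc(Nc4ccc(S(=O)(=O)C(C)C)cc4F)c3[N+](=O)[O-])CC2)n1` differs from compound 2 by methyl in place of hydrogen on a saturated chain carbon bound to a saturated chain carbon and a sulfonyl sulfur. Going by the values given here, the only measured step exchanged the sulfonyl alkyl together with the ring fluorine and read as a 1.1-fold lower number from compound 1 to compound 2 (0.05 log units; within the scatter), so compound 1 already carries the isopropylsulfonyl of compound 3 at a similar number. No step beyond the scatter is therefore expected, a 1.1-fold higher number from compound 2 to compound 3 (0.03 log units; within the scatter). Compound 3 is expected at 7.5 nM, within 3.5 nM to 16 nM.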

Compound 3, half-maximal effective concentration: 7.9 nM
Estimate against measurement, compound 3: 1.1-fold (0.02 log units) below, within the range that was stated.
By their numbers in this assay, from the lowest: compounds 2, 1 and 3 (each within the scatter of the next).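

The step from ethylsulfonyl to isopropylsulfonyl now stands alone in this assay, and a 1.1-fold higher number from compound 2 to compound 3 (0.05 log units; within the scatter) shows that this added methyl on the sulfonyl chain does not separate the two compounds. Fluoro in place of hydrogen on an aromatic carbon also stands alone for the first time, and a 1.0-fold higher number from compound 1 to compound 3 (0.01 log units; within the scatter) shows the same for this exchange. No evidence bears on why neither change separates its pair.

Still open, as far as these compounds go, is how the series responds to a longer chain or a cyclopropyl on the sulfonyl. From the compounds shown here alone, a chloro or methoxy in place of the fluoro is equally open.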